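Arylpiperazine sulfonyl-lactam series: forecast for pyrimidinyl analogue

The compounds below may be only part of what the source reports. "The series", "measured", "known", "first", "only" and "open" are said of these compounds alone.

Measured so far:
compound 1 `O=C1c2ccccc2S(=O)(=O)N1CCCCCCN1CCN(c2ccccc2Cl)CC1`: 459 nM
compound 2 `COc1cccc(N2CCN(CCCCCCN3C(=O)c4ccccc4S3(=O)=O)CC2)c1`: 921 nM
compound 3 `O=C1c2ccccc2S(=O)(=O)N1CCCCCCN1CCN(c2cccc3ccccc23)CC1`: 157 nM

All three share one core and differ only in the aryl group on the amine nitrogen in a ring. In an ADME assay on HEK293 cells for displacement of a labelled ligand from 5-hydroxytryptamine receptor 6 (Homo sapiens), read by radioligand binding, with a stated time of 1 h (a lower number here means a stronger inhibitor, a higher number a weaker inhibitor), compound 2 gives 921 nM, the highest number of the three; compound 1 sits nearest, with a 2.0-fold higher number from compound 1 to compound 2 (0.30 log units; within the scatter), and compound 3 furthest, with a 5.9-fold lower number from compound 2 to compound 3 (0.77 log units; beyond the scatter). The step of a 2.9-fold lower number from compound 1 to compound 3 (0.47 log units; beyond the scatter) points the same way, so of the three only the naphthalen-1-yl analogue stands apart from the other two.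

Compound 4 `O=C1c2ccccc2S(=O)(=O)N1CCCCCCN1CCN(c2ncccn2)CC1` is not yet measured. Its change from compound 2 is pyrimidin-2-yl in place of 3-methoxyphenyl on an amine nitrogen in a ring. Among the measured compounds shown here, none of the measured steps covers an exchange of this kind: the two steps beyond the scatter both enter naphthalen-1-yl, and the one exchange between two six-membered rings of carbon, from compound 1 to compound 2, stays within the scatter. The expectation for compound 4 in this assay is therefore a step from compound 2 of about a 1.6-fold higher number from compound 2 to compound 4 (0.21 log units; within the scatter), a weakening not clearly beyond the scatter, with wide uncertainty. Compound 4 is estimated at 1500 nM, with a range from 400 nM to 6000 nM.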

Compound 4, inhibition constant: 104 nM
Estimate against measurement, compound 4: 14-fold (1.16 log units) above; measured number below the stated range.
By their numbers in this assay, from the lowest: compounds 4 and 3 (each within the scatter of the next); then compounds 1 and 2 (each within the scatter of the next).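

Working notes, position on the amine nitrogen in a ring, in this assay: an aromatic ring with 2 hetero atoms is accepted here, since pyrimidin-2-yl gives a step beyond the scatter against both substituted phenyl groups (an 8.9-fold lower number from compound 2 to compound 4 (0.95 log units; beyond the scatter) and a 4.4-fold lower number from compound 1 to compound 4 (0.64 log units; beyond the scatter)), so naphthalen-1-yl is no longer the only group that stands apart. Pyrimidin-2-yl and naphthalen-1-yl cannot be told apart (a 1.5-fold lower number from compound 3 to compound 4 (0.18 log units; within the scatter)), so two quite different aryl groups, one with ring nitrogen and one of carbon only, fall together at the lower end of the series, and compounds 1 and 2 remain together at the upper end. Nothing available on these compounds accounts for this exchange.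

The compounds shown leave open whether the ring nitrogens of pyrimidin-2-yl carry the step, a question that a pyridin-2-yl group or an unsubstituted phenyl group on the same nitrogen would help to separate. They also leave open whether the pyrimidin-2-yl result holds with a shorter chain joining the piperazine-type ring to the rest of the shared core.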